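Swapping an Anilide for a Pentylamide: Expected Cytotoxicity

This account rests on a few compounds, and the source may have more. Where it says the series, first, only, none or still open, it means among the compounds named here.

Compound 1, `C=CC1=C(C(=O)NC(C)(C)C)C(c2ccc(OC)cc2)OC1`. In a functional assay on SW480 cells (Homo sapiens) for cytotoxicity, read by MTT assay, with a stated time of 24 h (a higher number here means a weaker inhibitor, a lower number a stronger inhibitor), compound 1 gives > 100000 nM, which is a limit of the assay rather than a number.
Compound 2, `C=CC1=C(C(=O)Nc2ccccc2)C(c2ccc(OC)cc2)OC1`. In this assay compound 2 gives > 100000 nM, again a limit rather than a number.
Compound 3, `C=CC1=C(C(=O)Nc2ccccc2)C(c2ccc(F)cc2)OC1`. In this assay compound 3 gives > 100000 nM, also a limit rather than a number.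

Compound 2 therefore stands at the limit shared by every measured compound, as the limit of > 100000 nM in this assay, at which 3 of the 3 values shown sit, records; no number sets it apart from compound 1 or from compound 3. The compound still to be measured is compound 4, `C=CC1=C(C(=O)NCCCCC)C(c2ccc(OC)cc2)OC1`. It differs from compound 2 by pentyl in place of phenyl on an amide-type nitrogen. The measured steps that touch the same amide-type nitrogen or the same shared core are a step that the two limits leave unreadable from compound 1 to compound 2 and a step that the two limits leave unreadable from compound 2 to compound 3; each runs from one limit to another, so its size cannot be read. Together they show that no change made so far, whether at the amide-type nitrogen or on the aromatic carbon, has brought a value into the measurable range. For compound 4 the expected outcome in this assay is therefore a step that the limit leaves unreadable from compound 2 to compound 4, meaning no change that the assay could register. The estimate for compound 4 is 150000 nM, with a range from 50000 nM to 500000 nM, most likely reported again as a limit.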

Compound 4, half-maximal inhibitory concentration: > 100000 nM
Compound 4 gave a limit, no number; the forecaster's own chance of this, stated with the estimate: 85%; the middle value does not contradict the limit.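

Compound 4 gives a limit rather than a number, so neither its step from compound 2 nor its step from compound 1 can be read, and it joins the other compounds at the same limit: the limit of > 100000 nM in this assay, at which 4 of the 4 values shown sit. Still open is how the true values of these compounds differ, and whether in this assay any change to the shared core would bring a value into the measurable range.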